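Fluoro to chloro on the fused ring of compound 2

The source may hold more compounds than are shown below. What is called first, only, known or untested is meant among the compounds shown, and "the series" means these compounds.

Measured so far:
compound 1 `N#Cc1ccc2c(Cl)cc(Oc3ccccc3OCCn3ccc(=O)[nH]c3=O)cc2c1` — 12000 nM
compound 2 `Cc1c(Oc2ccccc2OCCn2ccc(=O)[nH]c2=O)cc(F)c2ccc(C#N)cc12` — > 100000 nM

In a toxicity assay on MT2 cells (Homo sapiens) for cytotoxicity, read by MTT assay (on this read-out higher numbers stand for lower toxicity in this test and lower numbers for higher toxicity in this test), compound 1 gives 12000 nM. Compound 2 gives > 100000 nM, which is a limit of this assay and not a number, as noted in the limit of > 100000 nM in this assay, at which 1 of the 2 values shown sits. Within the data shown here, no step between measured compounds is available, and the two compounds differ in more than one place.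

Compound 3 `Cc1c(Oc2ccccc2OCCn2ccc(=O)[nH]c2=O)cc(Cl)c2ccc(C#N)cc12` carries the change (chloro in place of fluoro on an aromatic carbon). The step from compound 2 to compound 3 is expected to be modest, likely toward somewhat higher toxicity, an at least 1.2-fold lower number from compound 2 to compound 3 (0.09 log units; that floor lies within the scatter). Compound 3 is estimated at 80000 nM, between 20000 nM and 200000 nM.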

Compound 3, half-maximal cytotoxic concentration in the MT2 assay: > 100000 nM
Compound 3: a limit, no number (the forecaster's own chance of this, stated with the estimate: 55%); at least 1.2-fold (0.09 log units) between middle value and limit.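

With chloro in place of fluoro, in the MT2 assay compound 3 also gives > 100000 nM, which is a limit and not a number, so that step cannot be read: the limit of > 100000 nM in the MT2 assay, at which 2 of the 3 values shown sit.
The chloro pair instead isolates the methyl group, since in the MT2 assay methyl in place of hydrogen on an aromatic carbon gives an at least 8.3-fold higher number from compound 1 to compound 3 (0.92 log units; beyond the scatter), toward lower toxicity in this test. In a physicochemical assay for solubility, using the shake flask method, at pH 6.5 (on this read-out higher numbers stand for higher solubility and lower numbers for lower solubility), compound 2 gives 28.2 ug/mL and compound 3 gives 20.6 ug/mL. In the physicochemical assay, chloro in place of fluoro gives a 1.4-fold lower number from compound 2 to compound 3 (0.14 log units; within the scatter), so this read-out does not separate the two halogens.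

Going by these compounds, how far fluoro and chloro differ past the limit remains open. So does whether an ethyl or methoxy group in place of methyl would keep a compound at that limit.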